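From Cyclic Imide to (Dimethylsulfamoyl)amino: an Expected Solubility

A few compounds are considered here, and "the series" means these few. Any claim that something is new, unique, unknown or untested is made for them only; others in the source may bear on it.

Compound 1 `O=C1CCC(=O)N1C[C@H]1CN(c2ccc(-n3cc(-c4ccccn4)cn3)c(F)c2)C(=O)O1`: 45300 nM
Compound 2 `CCC(=O)NC[C@H]1CN(c2ccc(-n3cc(-c4ccccn4)cn3)c(F)c2)C(=O)O1`: 147000 nM

Of the compounds shown here, two have been measured in a physicochemical assay for solubility, read by HPLC, with a stated time of 24 h; on this read-out higher numbers stand for higher solubility and lower numbers for lower solubility. Compound 1 gives 45300 nM, the lowest of the two numbers, and compound 2 gives 147000 nM. Among the compounds with values here, the only measured step, a 3.2-fold higher number from compound 1 to compound 2 (0.51 log units; beyond the scatter), puts propanoylamino in place of 2,5-dioxopyrrolidin-1-yl on a saturated chain carbon bound to a saturated ring carbon.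

Compound 3 `CN(C)S(=O)(=O)NC[C@H]1CN(c2ccc(-n3cc(-c4ccccn4)cn3)c(F)c2)C(=O)O1` has not yet been measured. It differs from compound 1 in one place: (dimethylsulfamoyl)amino in place of 2,5-dioxopyrrolidin-1-yl on a saturated chain carbon bound to a saturated ring carbon. The step from compound 1 to compound 2 bears on this change, since in both cases the ring-bearing 2,5-dioxopyrrolidin-1-yl leaves the same position and an open-chain group carrying one hydrogen-bond donor enters. A rise of similar, modest size is therefore expected. Compound 3 is expected to give 120000 nM, with a range from 50000 nM to 300000 nM. The expected step is a 2.6-fold higher number from compound 1 to compound 3 (0.42 log units; beyond the scatter).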

Compound 3, solubility: 472000 nM
Estimate against measurement, compound 3: 3.9-fold (0.59 log units) below, and the stated range ends below it.
By their numbers in this assay, from the lowest: compound 1; then compound 2; then compound 3.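

In this assay, within the data shown here, the change at this place, on a saturated chain carbon bound to a saturated ring carbon, can go further than the earlier compounds showed: (dimethylsulfamoyl)amino in place of 2,5-dioxopyrrolidin-1-yl gives a 10-fold higher number from compound 1 to compound 3 (1.02 log units; beyond the scatter) on the same core. The group on the amine nitrogen also matters, since dimethylsulfamoyl in place of propanoyl gives a 3.2-fold higher number from compound 2 to compound 3 (0.51 log units; beyond the scatter), so the size of the rise on leaving the ring depends on which open-chain group enters. Nothing given here accounts for these differences.

The compounds shown leave open whether the rise needs the dimethylamino part of the new group, which a methanesulfonyl on the same amine nitrogen would test. They also leave open what a methyl on that nitrogen, in place of its hydrogen, would do to the number.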